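The compounds below may be only part of what the source reports. "The series", "measured", "known", "first", "only" and "open" are said of these compounds alone.

Compound 3 `CCc1cc(C(C)=O)c(O)cc1OCCCCCCSC` stands lowest of the three numbers in an assay on isolated protein for inhibition of leukotriene B4 receptor 1 (Homo sapiens), tested at 10 uM (a lower number here means less inhibition, a higher number more inhibition at the concentration tested (going by the name of the read-out)), where compound 3 gives 71%. Compound 1 `CCc1cc(C(C)=O)c(O)cc1OCCCCCC(C)(C)C#N` gives 85%. Compound 2 `CCc1cc(C(C)=O)c(O)cc1OCCCCCC(C)(C)C(=O)O` gives 104%. The step of a number 14 percentage points lower from compound 1 to compound 3 (beyond the scatter) is modest, the step of a number 33 percentage points lower from compound 2 to compound 3 (beyond the scatter) is large, and the step of a number 19 percentage points higher from compound 1 to compound 2 (beyond the scatter) is modest. Compound 4 `CCc1cc(C(C)=O)c(O)cc1OCCCCCn1cncn1` differs from compound 3 by 1H-1,2,4-triazol-1-yl in place of (methylsulfanyl)methyl on a saturated chain carbon, five bonds along the chain from an oxygen on an aromatic ring. Within the data shown here, no measured step replaces (methylsulfanyl)methyl with a ring; the nearest guides are the two steps into compound 3, which both run downward once (methylsulfanyl)methyl takes the terminal place. Reversing that direction, a modest rise in this assay is expected for compound 4, estimated at 80% with a range from 60% to 98%. The expected step is a number 9 percentage points higher from compound 3 to compound 4 (within the scatter).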

Compound 4, a percentage reported as inhibition, at one concentration (the size of the read-out at that concentration, not a potency): 82%
Estimate against measurement, compound 4: 2 percentage points below; the range from low to high includes it.
By their numbers in this assay, from the lowest: compound 3; then compounds 4 and 1 (each within the scatter of the next); then compound 2.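

In this assay, among these compounds, the 1H-1,2,4-triazol-1-yl end, the only ring at this place so far, gives a number 11 percentage points higher from compound 3 to compound 4 (beyond the scatter) and so reads above the (methylsulfanyl)methyl end, while a number 3 percentage points lower from compound 1 to compound 4 (within the scatter) leaves it level with the 1-cyano-1-methylethyl end. The 1-carboxy-1-methylethyl end stays apart, with a number 22 percentage points lower from compound 2 to compound 4 (beyond the scatter) separating it from the ring. Nothing at hand gives a reason for these steps.

Open, as far as these compounds go, is whether an imidazole, a tetrazole or an amine at the same place reads like the 1H-1,2,4-triazol-1-yl end. Also open, from the compounds shown here alone, is whether a longer chain carrying this ring keeps the same reading.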